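The source may hold more compounds than are shown below. What is called first, only, known or untested is meant among the compounds shown, and "the series" means these compounds.

In a functional assay on HCT-8 cells (Homo sapiens) for antiproliferative activity, read by MTT assay, with a stated time of 48 h (on this read-out higher numbers stand for weaker inhibition and lower numbers for stronger inhibition), compound 1 `COc1ccc(C(=O)c2ccc(OC)c3c2OC(C)(C)C=C3)c(NC(=O)CN)c1` gives 370 nM, and its methylated counterpart compound 3 `CNCC(=O)Nc1cc(OC)ccc1C(=O)c1ccc(OC)c2c1OC(C)(C)C=C2` gives 740 nM; the change between them, (methyl in place of hydrogen on an amine nitrogen), produced a 2.0-fold higher number from compound 1 to compound 3 (0.30 log units; within the scatter). Compound 2 `COc1ccc(C(=O)c2ccc3c(c2)C=CC(C)(C)O3)c(NC(=O)CN)c1` carries a different core, and how the two cores differ is not broken down here; in this assay compound 2 gives 490 nM, which lies within the scatter of compound 1. The same change, (methyl in place of hydrogen on an amine nitrogen), is made on the core of compound 2 to give compound 4 `CNCC(=O)Nc1cc(OC)ccc1C(=O)c1ccc2c(c1)C=CC(C)(C)O2`, which has not yet been measured in this assay. The step from compound 2 to compound 4 is expected to be a 1.9-fold higher number from compound 2 to compound 4 (0.29 log units; within the scatter), resting on the step from compound 1 to compound 3 a 2.0-fold higher number from compound 1 to compound 3 (0.30 log units; within the scatter). Compound 4 is therefore estimated at 950 nM in this assay, between 450 nM and 2000 nM.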

Compound 4, half-maximal inhibitory concentration: 1010 nM
The estimate for compound 4 lay 1.1-fold (0.03 log units) below the measured number; measured number inside the range.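

In this assay, methyl in place of hydrogen on the amine nitrogen gave a 2.1-fold higher number from compound 2 to compound 4 (0.31 log units; beyond the scatter), and the change carried over from one core to the other at much the same size: the same change on two cores in this assay, a 2.0-fold higher number (0.30 log units; within the scatter) from compound 1 to compound 3 and a 2.1-fold higher number (0.31 log units; beyond the scatter) from compound 2 to compound 4, 1.0-fold (0.01 log units) apart, within the scatter of two such steps. One step lies within the scatter and the other only just beyond it, so the two together show a small shift that repeats rather than a large effect. This rests on one change and two cores, and it shows nothing about how the change would read on any further core or in any other test.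

The compounds shown leave open what an ethyl group or a second methyl on that nitrogen would give. Also open, going by these compounds, is how a longer chain carrying the amine, or a hydroxyl group in place of the amine, would read.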